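This account rests on a few compounds, and the source may have more. Where it says the series, first, only, none or still open, it means among the compounds named here.

For the measured compounds named here, compound 1 `COc1ccc(Br)cc1-c1nc(N)nc(N)n1` is one of two compounds measured in a functional assay on the whole organism with Rattus norvegicus as the target, at a dose of 20 mg/kg by the intraperitoneal route (a lower number here means less inhibition, a higher number more inhibition at the dose given (going by the name of the read-out)), where compound 1 gives 49%. Compound 2 `Nc1nc(N)nc(-c2cc(Br)ccc2Cl)n1` gives 86% in this assay, and the step of a number 37 percentage points higher from compound 1 to compound 2 (beyond the scatter) is the only one recorded. Compound 1 therefore stands as the lower of the two numbers.

Compound 3 `COc1ccccc1-c1nc(N)nc(N)n1` differs from compound 1 by a single change: hydrogen in place of bromo on an aromatic carbon. Going by the values given here, the one measured step concerns a different group, chloro in place of methoxy on an aromatic carbon, so no recorded step tells directly what removing the bromo will do. With nothing to build on, the most defensible expectation is that compound 3 stays close to compound 1, with a modest loss of inhibition possible, and the estimated step is a number 9 percentage points lower from compound 1 to compound 3 (within the scatter). Compound 3 is thus expected to give about 40%, within a wide range from 15% to 70%.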

Compound 3, a percentage reported as inhibition, in the whole organism at one dose (the size of the read-out at that dose, not a potency): 1%
Beside the measured number, compound 3's estimate is 39 percentage points above it; measured number below the stated range.
By their numbers in this assay, from the lowest: compound 3; then compound 1; then compound 2.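

Replacing the bromo, para to a methoxy group, with hydrogen gives a number 48 percentage points lower from compound 1 to compound 3 (beyond the scatter) in this assay and leaves compound 3 at 1% with almost no inhibition at this dose. This position is therefore far from neutral: in this pair, a change of one heavy atom on the ring removes nearly all of the effect seen with compound 1. For the compounds shown here, the earlier step concerned the methoxy group, so this is the first measured sign that the bromo position also matters, although no measurement here explains the loss.

Going by these compounds, it remains open whether bromine itself is needed or whether another group at this position, such as chloro, methyl or an amine, would restore the inhibition. On these data alone, it is also open whether hydrogen in place of bromo would cost as much in compound 2, which carries chloro instead of methoxy.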